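Notes on the amide substituent step to compound 3

The source may report more compounds than this note shows. Statements on the series, on what has been measured and on what is new or still open speak of the compounds shown alone.

Measured compounds:
compound 1, `CC(C)C[C@H](N)c1cc(C(F)(F)F)ccc1N1CCN(C(=O)CCC(N)=O)CC1`, in an assay on HEK293 cells for displacement of a labelled ligand from Melanocortin receptor 4 (Homo sapiens) (a lower number here means a stronger inhibitor, a higher number a weaker inhibitor), compound 1 gives > 10000 nM, a limit of the assay.
compound 2, `CC(C)C[C@H](N)c1cc(C(F)(F)F)ccc1N1CCN(C(=O)CCC(=O)N(C)C)CC1`, in this assay compound 2 gives > 10000 nM, also a limit.

Compound 2 therefore has no number in this assay, only the limit; both values shown sit at it, as noted in the limit of > 10000 nM in this assay, at which 2 of the 2 values shown sit. Within the data shown here, the one measured step, a step that the two limits leave unreadable from compound 1 to compound 2, cannot be read because both ends are limits, so no step size is known for this series.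

Compound 3, `COc1ccc(CC(C)C(=O)N2CCN(c3ccc(C(F)(F)F)cc3[C@@H](N)CC(C)C)CC2)cc1`, differs from compound 2 by 1-(4-methoxybenzyl)ethyl in place of 2-(dimethylcarbamoyl)ethyl on a carbonyl carbon. Among the measured compounds shown here, no measured step bears on this change: the only step known involves a different change on the same carbonyl carbon and is itself unreadable. With compound 2 at the limit, the direction of the step to compound 3 in this assay cannot be read from the data, and a step of any size remains possible; a return below the limit is expected only as a guess. Compound 3 is expected to give about 3000 nM in this assay, with a range from 300 nM to 20000 nM, which would correspond to an expected step of an at least 3.3-fold lower number from compound 2 to compound 3 (0.52 log units; beyond the scatter).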

Compound 3, inhibition constant: 120 nM
The estimate for compound 3 lay 25-fold (1.40 log units) above the measured number; the whole stated range lies above it.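

In this assay, this carbonyl carbon proves able to bring the series off the limit: 1-(4-methoxybenzyl)ethyl in place of 2-(dimethylcarbamoyl)ethyl gives an at least 83-fold lower number from compound 2 to compound 3 (1.92 log units; beyond the scatter), and the same group in place of 2-carbamoylethyl gives an at least 83-fold lower number from compound 1 to compound 3 (1.92 log units; beyond the scatter). The step between the two earlier compounds cannot be read, so they showed only that two amide-bearing chains leave the series at the limit, and compound 3 alone gives a number: the limit of > 10000 nM in this assay, at which 2 of the 3 values shown sit. The entering group holds a six-membered aromatic ring of carbon only and 2-(dimethylcarbamoyl)ethyl holds no ring, but the ring, the methoxy group and the branching methyl all arrive in a single change, so the size of the step cannot be assigned to any one of them.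

A plain benzyl group, without the methoxy group and the branching methyl, would begin to separate these contributions. Also open, on these data alone, is whether a hydroxy group in place of the methoxy group, or a longer chain leading to the ring, would keep compound 3 near 120 nM.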